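Working notes: nitro to amino in the antiproliferative series

A few compounds are considered here, and "the series" means these few. Any claim that something is new, unique, unknown or untested is made for them only; others in the source may bear on it.

Measured so far:
compound 1 `COc1ccc(CS(=O)(=O)/C=C/c2ccc(Cl)cc2)cc1` gives 3500 nM
compound 2 `COc1ccc(CS(=O)(=O)/C=C/c2ccc([N+](=O)[O-])cc2)cc1` gives 7500 nM

Both numbers come from a functional assay on H157 cells (Homo sapiens) for antiproliferative activity, read by trypan blue exclusion; on this read-out higher numbers stand for weaker inhibition and lower numbers for stronger inhibition. Within the data shown here, compound 2 holds the higher of the two numbers; the only step measured, a 2.1-fold higher number from compound 1 to compound 2 (0.33 log units; beyond the scatter), is modest but beyond the scatter.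

Compound 3 `COc1ccc(CS(=O)(=O)/C=C/c2ccc(N)cc2)cc1` has not been measured. It differs from compound 2 by amino in place of nitro on an aromatic carbon.

Among the measured compounds shown here, no measured step bears on this change: the one step recorded, from compound 1 to compound 2, swaps chloro for nitro, and nothing shows what happens when nitro gives way to amino. For the measured compounds named here, the sole step seen, a 2.1-fold higher number from compound 1 to compound 2 (0.33 log units; beyond the scatter), was modest, so a change of similar modest size in either direction, or none beyond the scatter, is the most that can be expected for this assay. The working expectation is a step of a 1.3-fold lower number from compound 2 to compound 3 (0.10 log units; within the scatter), carrying wide uncertainty. Compound 3 is therefore estimated at 6000 nM, with a plausible range from 2000 nM to 20000 nM.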

Compound 3, half-maximal inhibitory concentration: > 20000 nM
Compound 3 ended at the assay's limit (the forecaster's own chance of this, stated with the estimate: 10%); at least 3.3-fold (0.52 log units) between middle value and limit.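

In this assay compound 3 gives > 20000 nM, which is a limit of the assay and not a number: the limit of > 20000 nM in this assay, at which 1 of the 3 values shown sits. Amino in place of nitro gives an at least 2.6-fold higher number from compound 2 to compound 3 (0.42 log units; beyond the scatter), and amino in place of chloro gives an at least 5.7-fold higher number from compound 1 to compound 3 (0.75 log units; beyond the scatter), so the group on this aromatic carbon, para to a large group, can move the read-out further than the earlier step alone, a 2.1-fold higher number from compound 1 to compound 2 (0.33 log units; beyond the scatter), had shown. Among these three compounds, the amino compound 3 shows the weakest inhibition, with both of its steps beyond the scatter.

Going by these compounds, how far compound 3 lies past the limit remains unknown. Also open, on these data alone, is whether an acetamide, a dimethylamino group or a hydroxyl group at this same place would stay near the nitro and chloro compounds or fall to the limit as well.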